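The source may hold more compounds than are shown below. What is called first, only, known or untested is meant among the compounds shown, and "the series" means these compounds.

Measured so far in a functional assay on NCI-H23 cells (Homo sapiens) for inhibition, read by sulforhodamine B assay, with a stated time of 48 h; on this read-out lower numbers stand for stronger inhibition of growth and higher numbers for weaker inhibition of growth:
compound 1 `Nc1cc(N)c2nc(-c3ccccc3)c(Oc3ccc(Cl)c(Cl)c3)nc2c1` gives 39800 nM
compound 2 `Nc1cc(N)c2nc(-c3ccccc3)c(NCc3ccc(Cl)c(Cl)c3)nc2c1` gives 27500 nM
compound 3 `CCOC(=O)[C@H](CCC(=O)O)NC(=O)c1ccc(Sc2nc3cc(N)cc(N)c3nc2-c2ccccc2)cc1` gives 33900 nM

Compound 1 carries the highest of the three numbers, but its gaps to compound 3 and to compound 2 both fall within the usual scatter, so the three compounds stand level in this assay. Compound 4 `Nc1cc(N)c2nc(-c3ccccc3)c(Sc3ccc(Cl)c(Cl)c3)nc2c1` is still to be measured; it differs from compound 1 by (3,4-dichlorophenyl)sulfanyl in place of 3,4-dichlorophenoxy on an aromatic carbon. Among the compounds with values here, no measured pair shows this exchange on its own. Compound 3, whose aryl group also hangs from a sulfanyl link to the shared core, gives 33900 nM, close to compound 1 at 39800 nM; on that basis no step beyond the scatter is expected from compound 1 to compound 4. Compound 4 is expected to give about 35000 nM, within 12000 nM to 100000 nM. The expected step from compound 1 to compound 4 is thus a 1.1-fold lower number from compound 1 to compound 4 (0.06 log units; within the scatter).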

Compound 4, concentration for total growth inhibition: 34700 nM
Beside the measured number, compound 4's estimate is 1.0-fold (0.00 log units) above it; measured number inside the range.
By their numbers in this assay, from the lowest: compounds 2, 3, 4 and 1 (each within the scatter of the next).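

In this assay, within the data shown here, the exchange of 3,4-dichlorophenoxy for (3,4-dichlorophenyl)sulfanyl on this aromatic carbon gives a direct reading that no earlier pair offered: a 1.1-fold lower number from compound 1 to compound 4 (0.06 log units; within the scatter). At this position, oxygen and sulfur as the linking atom to the dichlorophenyl ring therefore cannot be told apart on this read-out. No measured evidence bears on this result. As far as these compounds go, whether an amine or a carboxylic acid in place of the chlorine atoms, or a longer chain to the shared core, would move the number remains open.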